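Replacing chlorine with fluorine in compound 2

The source may hold more compounds than are shown below. What is called first, only, known or untested is meant among the compounds shown, and "the series" means these compounds.

Measured so far in a functional assay on RT-112 cells (Homo sapiens) for antiproliferative activity, read by MTT assay, with a stated time of 72 h; a higher number here means a weaker inhibitor of growth, a lower number a stronger inhibitor of growth
- compound 1 `COc1cc(Nc2ncnc3c(NC(=O)Nc4cccc(Cl)c4Cl)cccc23)cc(OC)c1` gives 63.2 nM
- compound 2 `COc1cc(Nc2ncnc3c(NC(=O)Nc4cc(Cl)cc(Cl)c4)cccc23)cc(OC)c1` gives 30.2 nM

Compound 2 has the lower of the two numbers, which makes it the stronger inhibitor of growth so far. The next compound, compound 3 `COc1cc(Nc2ncnc3c(NC(=O)Nc4cc(F)cc(F)c4)cccc23)cc(OC)c1`, carries one change: 3,5-difluorophenyl in place of 3,5-dichlorophenyl on an amide-type nitrogen. In words, 3,5-difluorophenyl stands in place of 3,5-dichlorophenyl on an amide-type nitrogen.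

For the measured compounds named here, only one measured step can serve as a guide. That step, a 2.1-fold lower number from compound 1 to compound 2 (0.32 log units; beyond the scatter), exchanged one dichlorophenyl group for another. Going by the values given here, it bears on the new change only loosely, as no measured pair shows fluorine replacing chlorine. Taking the size of a 2.1-fold lower number from compound 1 to compound 2 (0.32 log units; beyond the scatter) as a rough yardstick, a modest step is expected in this assay, more likely toward a higher number, as compound 2 at 30.2 nM is the lowest value so far. The direction remains uncertain, and the range is kept wide. The expected change is a 1.8-fold higher number from compound 2 to compound 3 (0.26 log units; within the scatter) by this estimate. Compound 3 is estimated at 55 nM with an expected range of 18 nM to 170 nM for a single measurement.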

Compound 3, concentration for 50% growth inhibition: 2630 nM
Estimate against measurement, compound 3: 48-fold (1.68 log units) below; measured number above the stated range.
By their numbers in this assay, from the lowest: compound 2; then compound 1; then compound 3.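

With the placing of the two halogens held the same, 3,5-difluorophenyl in place of 3,5-dichlorophenyl on the amide-type nitrogen gives an 87-fold higher number from compound 2 to compound 3 (1.94 log units; beyond the scatter) in this assay, so the choice of halogen counts for far more here than the exchange of one dichlorophenyl group for another, which gave a 2.1-fold lower number from compound 1 to compound 2 (0.32 log units; beyond the scatter) in the same assay. The 3,5-difluorophenyl group also compares poorly with the 2,3-dichlorophenyl group, with a 42-fold higher number from compound 1 to compound 3 (1.62 log units; beyond the scatter), so among these three compounds both groups carrying chlorine give much stronger growth inhibition than the group carrying fluorine, however the chlorines are placed. Nothing available explains why the exchange of chlorine for fluorine has so large an effect.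

The compounds shown leave open whether it is the presence of chlorine itself that matters, which a 3-chloro-5-fluorophenyl group, carrying one of each halogen, could help to test. They also leave open whether other groups on this ring, such as 3,5-dibromophenyl or 3,5-dimethylphenyl, would match or pass compound 2 at this position.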